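A Third Methoxy on the Fused Ring of Compound 3

The source may hold more compounds than are shown below. What is called first, only, known or untested is meant among the compounds shown, and "the series" means these compounds.

Compound 1 `COC(=O)C(CCCN1CCc2cc(OC)c(OC)cc2C1)(Sc1ccc(C)cc1)c1ccc(OC)c(OC)c1`: 1470 nM
Compound 2 `COc1ccc2c(c1)CCN(CCCCCC(Sc1ccc(C)cc1)c1ccc(OC)c(OC)c1)C2`: 3090 nM
Compound 3 `COc1ccc(C(CCCCCCN2CCc3cc(OC)c(OC)cc3C2)Sc2ccc(C)cc2)cc1OC`: 900 nM

In a functional assay on S1B1-20 cells (Homo sapiens) (on this read-out higher numbers stand for weaker inhibition and lower numbers for stronger inhibition), compound 3 gives the lowest of the three numbers. Compound 1, with 1470 nM, lies within the scatter of compound 3, so no order between the two can be claimed. Compound 2, with 3090 nM, stands beyond the scatter, a weaker inhibitor than compound 3.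

Compound 4 `COc1ccc(C(CCCCCCN2CCc3cc(OC)c(OC)c(OC)c3C2)Sc2ccc(C)cc2)cc1OC` differs from compound 3 by methoxy in place of hydrogen on an aromatic carbon. Among the measured compounds shown here, no pair of measured compounds isolates this change, so its size cannot be read from the data. The step is expected to be small, in either direction, and likely not beyond the scatter. For compound 4 the estimate in this assay is 1000 nM, with a range from 400 nM to 2500 nM, which means an expected step of a 1.1-fold higher number from compound 3 to compound 4 (0.05 log units; within the scatter).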

Compound 4, half-maximal inhibitory concentration: 700 nM
Beside the measured number, compound 4's estimate is 1.4-fold (0.15 log units) above it, within the range that was stated.
By their numbers in this assay, from the lowest: compounds 4, 3 and 1 (each within the scatter of the next, the first and the last beyond it); then compound 2.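

In this assay, among the compounds shown here, methoxy in place of hydrogen, on the aromatic carbon ortho to a fused ring, gives a 1.3-fold lower number from compound 3 to compound 4 (0.11 log units; within the scatter) and so forms the first pair of measured compounds that isolates this change. At this position a third methoxy on the shared core leaves compound 4 within the scatter of compound 3, with no gain or loss that can be claimed. Nothing at hand gives a cause for this result. On these data alone, how a hydroxyl, an amine or a carboxylic acid on this carbon would read in this assay remains open, as does an ethoxy in place of the new methoxy.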